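Bromine in place of hydroxy on the aryl ester ring

A few compounds are considered here, and "the series" means these few. Any claim that something is new, unique, unknown or untested is made for them only; others in the source may bear on it.

Three analogues sharing one core have been measured in a functional assay on cells (T-cell, Mus musculus, strain BALB/c) for inhibition, read by MTT assay, with a stated time of 72 h; on this read-out lower numbers stand for stronger inhibition and higher numbers for weaker inhibition. Compound 1 `COC(=O)c1cc(Cl)ccc1OC(=O)COc1cc(O)c2c(=O)cc(-c3ccccc3)oc2c1` gives 3740 nM, compound 2 `COC(=O)c1c(Br)cc(Br)cc1OC(=O)COc1cc(O)c2c(=O)cc(-c3ccccc3)oc2c1` gives 45700 nM, and compound 3 `COC(=O)c1cc(O)ccc1OC(=O)COc1cc(O)c2c(=O)cc(-c3ccccc3)oc2c1` gives 29500 nM. On these numbers compound 3 stands second highest: compound 2 lies within the scatter of it, while compound 1 lies beyond it, the difference being a 7.9-fold higher number from compound 1 to compound 3 (0.90 log units; beyond the scatter).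

Compound 4 `COC(=O)c1c(Br)cccc1OC(=O)COc1cc(O)c2c(=O)cc(-c3ccccc3)oc2c1` has not been measured. It differs from compound 3 as a group of 11 heavy atoms (8 carbon, 2 oxygen, 1 bromine; one six-membered aromatic ring of carbon only) in place of a group of 11 heavy atoms (8 carbon, 3 oxygen; one six-membered aromatic ring of carbon only), on an oxygen next to a carbonyl group.

Two comparisons bear on this change. For the measured compounds named here, the only counted step, a 7.9-fold higher number from compound 1 to compound 3 (0.90 log units; beyond the scatter), shows that a chloro in place of a hydroxy on the aryl ester ring went with a markedly lower number. The two values of compound 2 and compound 3, by contrast, show that two bromines gave a number within the scatter of the hydroxy compound. A single bromine is therefore expected to land between these outcomes, with the step of a 2.5-fold lower number from compound 3 to compound 4 (0.39 log units; beyond the scatter) expected to be a lowering of modest size. Compound 4 is expected to give 12000 nM, within 3000 nM to 45000 nM.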

Compound 4, half-maximal inhibitory concentration: 41700 nM
Compound 4: the middle estimate sits 3.5-fold (0.54 log units) below what was measured, and the stated range covers the measured number.
By their numbers in this assay, from the lowest: compound 1; then compounds 3, 4 and 2 (each within the scatter of the next).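

In this assay, the single bromine does not set compound 4 apart from the hydroxy analogue (a 1.4-fold higher number from compound 3 to compound 4 (0.15 log units; within the scatter)), a result within the scatter. Taking away one bromine from the dibrominated ring also leaves the number within the scatter (a 1.1-fold lower number from compound 2 to compound 4 (0.04 log units; within the scatter)), so on this ring the second bromine makes no readable difference. A bromo group alone therefore does not reproduce the low number of the chloro analogue (an 11-fold higher number from compound 1 to compound 4 (1.05 log units; beyond the scatter)), and compound 1 remains alone among the four, with compounds 2, 3 and 4 forming a group that cannot be ordered.

Still open, as far as these compounds go, is whether that low number belongs to the chloro group itself or to where it sits on the ring, and how a fluoro or an amino group there would read. The data at hand offer no explanation for any of these steps.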